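A few compounds are considered here, and "the series" means these few. Any claim that something is new, unique, unknown or untested is made for them only; others in the source may bear on it.

Measured so far:
compound 1: `COc1cccc(-n2cc(NC(=O)c3cccc(NS(=O)(=O)c4ccccc4)c3)cn2)c1` — 25000 nM
compound 2: `COc1cccc(-n2cc(NC(=O)c3cccc(NS(=O)(=O)c4ccc(Cl)cc4)c3)cn2)c1` — 19600 nM
compound 3: `Cn1cc(NC(=O)c2ccc(NS(=O)(=O)c3ccccc3)cc2)cn1` — > 100000 nM

In a functional assay on HepG2 cells (Homo sapiens) for inhibition, read by MTT assay, with a stated time of 48 h (a lower number here means a stronger inhibitor, a higher number a weaker inhibitor), compound 1 gives 25000 nM. Compound 2, which carries chloro in place of hydrogen on an aromatic carbon, gives 19600 nM, and the step is a 1.3-fold lower number from compound 1 to compound 2 (0.11 log units; within the scatter). For compound 3 the assay reports no number but only a limit, > 100000 nM, and this is the limit of > 100000 nM in this assay, at which 1 of the 3 values shown sits. Compound 3 therefore stands at the weak end of what has been measured, and its true value is not known.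

Compound 4, `COc1ccc(-n2cc(NC(=O)c3ccc(NS(=O)(=O)c4ccccc4)cc3)cn2)cc1`, differs from compound 3 by 4-methoxyphenyl in place of methyl on an aromatic nitrogen. Going by the values given here, the only measured step, the chloro exchange between compound 1 and compound 2, touches a different part of the molecule and was within the scatter, so it says nothing directly about an exchange on the ring nitrogen. What can be drawn on is that compound 1, which also carries a methoxyphenyl group on that nitrogen, gives 25000 nM. Compound 4 is therefore expected to give roughly 40000 nM, in a range from 15000 nM to 110000 nM, which would mean an estimated at least 2.5-fold lower number from compound 3 to compound 4 (0.39 log units; beyond the scatter), though a further limit remains quite possible.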

Compound 4, half-maximal inhibitory concentration: 57300 nM
The estimate for compound 4 lay 1.4-fold (0.16 log units) below the measured number; the measured number falls inside the stated range.
By their numbers in this assay, from the lowest: compounds 2 and 1 (each within the scatter of the next); then compound 4. At a limit, above all of these: compound 3.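

Going by these compounds alone, replacing methyl with 4-methoxyphenyl on the aromatic nitrogen gives an at least 1.7-fold lower number from compound 3 to compound 4 (0.24 log units; that floor lies within the scatter) in this assay and provides the first view of a change at this position. The earlier chloro exchange sat elsewhere on the molecule, whereas this change brings compound 4 to a measured number, so a large aromatic group on this nitrogen is compatible with a readable value in the assay. The step can only be read as a floor, with its true size unknown, because compound 3 rests at a limit: the limit of > 100000 nM in this assay, at which 1 of the 4 values shown sits.

The methoxy group and the six-membered aromatic ring enter together in this one change, so the compounds shown leave open how much each part contributes, and a plain phenyl group on the same nitrogen would be needed to separate them. They also leave open whether this nitrogen accepts quite different groups, such as a longer alkyl chain, an amine or a carboxylic acid, and how those would compare with methyl and 4-methoxyphenyl.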